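Moving and swapping a halogen on the aryl ring

The compounds below may be only part of what the source reports. "The series", "measured", "known", "first", "only" and "open" are said of these compounds alone.

Of the compounds shown here, three built on one shared core have been tested in an assay on isolated protein for inhibition of Indoleamine 2,3-dioxygenase 1 (Homo sapiens), read by spectrophotometry, with a stated time of 1 h; on this read-out higher numbers stand for weaker inhibition and lower numbers for stronger inhibition. Compound 1 `O=[N+]([O-])c1ccc(N/C(=N\O)c2cccc(F)c2)c2nonc12` gives 75 nM in this assay. Compound 2 `O=[N+]([O-])c1ccc(N/C(=N\O)c2cccc(Cl)c2)c2nonc12` gives 184 nM in this assay. Compound 3 `O=[N+]([O-])c1ccc(N/C(=N\O)c2cccc(Br)c2)c2nonc12` gives 105 nM in this assay. Compound 3 holds the second highest of the three numbers; its nearest neighbour is compound 1 and its furthest is compound 2, and both gaps fall within the scatter of repeated measurements, so no order can be read among them. Among the measured compounds shown here, the only step that reaches beyond the scatter is a 2.5-fold higher number from compound 1 to compound 2 (0.39 log units; beyond the scatter), a modest one. The steps of a 1.4-fold higher number from compound 1 to compound 3 (0.15 log units; within the scatter) and a 1.8-fold lower number from compound 2 to compound 3 (0.24 log units; within the scatter) stay within the scatter.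

Compound 4 `O=[N+]([O-])c1ccc(N/C(=N\O)c2ccc(Cl)cc2)c2nonc12` has not yet been measured. It differs from compound 3 in one place: 4-chlorophenyl in place of 3-bromophenyl on a carbon with a double bond to nitrogen. Two things change together here, the halogen itself and where on the ring it sits. Exchanging one halogen for another is covered by the measured steps, all of them small; shifting its position is covered by none of them. Compound 4 is therefore expected to give about 150 nM in this assay, within a range of 50 nM to 500 nM, because a 1.8-fold lower number from compound 2 to compound 3 (0.24 log units; within the scatter) stayed within the scatter. The expected step of a 1.4-fold higher number from compound 3 to compound 4 (0.15 log units; within the scatter) is small, with no firm direction.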

Compound 4, half-maximal inhibitory concentration: 113 nM
The estimate for compound 4 lay 1.3-fold (0.12 log units) above the measured number; measured number inside the range.
By their numbers in this assay, from the lowest: compounds 1, 3, 4 and 2 (each within the scatter of the next, the first and the last beyond it).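

Among the compounds shown here, replacing 3-chlorophenyl with 4-chlorophenyl keeps the halogen and alters only where it sits on the ring, so this is the first clean look at position: in this assay it gives a 1.6-fold lower number from compound 2 to compound 4 (0.21 log units; within the scatter), and this shift of the chlorine cannot be told apart from the spread of repeat measurements. The other two new comparisons, a 1.1-fold higher number from compound 3 to compound 4 (0.03 log units; within the scatter) and a 1.5-fold higher number from compound 1 to compound 4 (0.18 log units; within the scatter), change the halogen and its position together and also stay within the scatter, so in this assay the 4-chlorophenyl group reads like the 3-bromophenyl, 3-chlorophenyl and 3-fluorophenyl groups on this carbon with a double bond to nitrogen. No other measurement is available that could explain why these four aryl groups read so alike.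

Every aryl group shown carries a single halogen, so it remains open how this assay would read a plain phenyl ring with no halogen, or a ring bearing a methoxy group, a nitrile or an amine instead. A ring carrying two halogens at once also lies outside these compounds, so the tolerance seen here is known only for single halogens.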